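Chain on the ring nitrogen: compound 3 to compound 4

The source may hold more compounds than are shown below. What is called first, only, known or untested is meant among the compounds shown, and "the series" means these compounds.

Working notes on the series. The three measured compounds share one core and differ only in the chain on the ring nitrogen. Compound 1 `CN1CCN(c2nc3ccccc3n2CCOc2ccccc2)CC1` gives 6.9 nM in a functional assay on ileum for inhibition of histamine H1 receptor (Cavia porcellus); on this read-out higher numbers stand for weaker inhibition and lower numbers for stronger inhibition. Compound 2 `CCCCCCCn1c(N2CCN(C)CC2)nc2ccccc21` gives 150 nM in this assay, and compound 3 `COCCCn1c(N2CCN(C)CC2)nc2ccccc21` gives 860 nM. Compound 3 thus stands at the highest number of the three: its nearest neighbour is compound 2, with a 5.7-fold higher number from compound 2 to compound 3 (0.76 log units; beyond the scatter), and the widest gap is to compound 1, with a 120-fold higher number from compound 1 to compound 3 (2.10 log units; beyond the scatter).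

Compound 4 `CCCC(C)n1c(N2CCN(C)CC2)nc2ccccc21` is not yet measured. It differs from compound 3 in one place: 1-methylbutyl in place of 3-methoxypropyl on an aromatic nitrogen. The step bearing most directly on this change is a 5.7-fold higher number from compound 2 to compound 3 (0.76 log units; beyond the scatter), which runs in the opposite direction, trading an all-carbon chain for one carrying an acceptor. Compound 4 returns to an all-carbon chain, though 1-methylbutyl is shorter than the heptyl of compound 2. The steps of a 22-fold higher number from compound 1 to compound 2 (1.34 log units; beyond the scatter) and a 120-fold higher number from compound 1 to compound 3 (2.10 log units; beyond the scatter) concern the phenoxy group and bear only indirectly. A modest downward step in this assay is therefore expected, a 3.4-fold lower number from compound 3 to compound 4 (0.54 log units; beyond the scatter). A full return to the number of compound 2 is not assumed. Compound 4 is estimated at 250 nM in this assay, with a range of 80 nM to 900 nM.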

Compound 4, half-maximal inhibitory concentration: 1400 nM
Compound 4: middle estimate off by 5.6-fold (0.75 log units), on the low side, and the stated range ends below it.
By their numbers in this assay, from the lowest: compound 1; then compound 2; then compounds 3 and 4 (each within the scatter of the next).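

In this assay, 1-methylbutyl in place of 3-methoxypropyl on the aromatic nitrogen gives a 1.6-fold higher number from compound 3 to compound 4 (0.21 log units; within the scatter) so these two chains, each of 5 heavy atoms, are not separated here even though only 3-methoxypropyl carries a hydrogen-bond acceptor. An all-carbon chain on this nitrogen is therefore not enough to reach the number of compound 2, since 1-methylbutyl in place of heptyl gives a 9.3-fold higher number from compound 2 to compound 4 (0.97 log units; beyond the scatter) and the two all-carbon chains are clearly distinguished in this assay. Nothing on hand offers an explanation for either step.

The compounds shown leave open whether the gap between heptyl and 1-methylbutyl follows the length of the chain or its methyl branch, a question that an unbranched pentyl chain on the same nitrogen would help to settle. They also leave open how this position responds to a chain ending in a dimethylamino group or a carboxylic acid, neither of which is among the chains shown here.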